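The source may hold more compounds than are shown below. What is called first, only, known or untested is meant among the compounds shown, and "the series" means these compounds.

Measured so far in a functional assay on PC-3 cells (Homo sapiens) for antiproliferative activity, read by MTT assay, with a stated time of 12 h; on this read-out lower numbers stand for stronger inhibition and higher numbers for weaker inhibition:
compound 1 `COc1ccc2oc(/C=C/c3ccc(OC(F)(F)F)cc3)cc(=O)c2c1` gives > 40000 nM;
compound 2 `COc1cccc2oc(/C=C/c3ccc(OC(F)(F)F)cc3)cc(=O)c12` gives > 40000 nM.

For compound 1 this value is a limit of the assay, not a number. For compound 2 it is likewise a limit. Compound 2 therefore stands at the limit of > 40000 nM in this assay, at which 2 of the 2 values shown sit.

Compound 3 `O=c1cc(/C=C/c2ccc(OC(F)(F)F)cc2)oc2ccccc12` differs from compound 2 by hydrogen in place of methoxy on an aromatic carbon. Among the compounds with values here, no step between measured compounds is available to guide this change. In this assay the expected step from compound 2 to compound 3 is a step that the limit leaves unreadable from compound 2 to compound 3, nothing beyond the scatter in either direction. Compound 3 is estimated at 60000 nM, in a range from 20000 nM to 200000 nM, and is expected most likely to be reported again only as a limit.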

Compound 3, half-maximal inhibitory concentration: 28900 nM
Beside the measured number, compound 3's estimate is 2.1-fold (0.32 log units) above it; the range from low to high includes it.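

In this assay compound 3, with hydrogen in place of methoxy on an aromatic carbon, gives 28900 nM, a true number rather than a limit. Hydrogen in place of methoxy gives an at least 1.3-fold lower number from compound 2 to compound 3 (0.14 log units; that floor lies within the scatter), and likewise an at least 1.3-fold lower number from compound 1 to compound 3 (0.14 log units; that floor lies within the scatter); these are only floors, so the full size of either step cannot be read. Compound 1 and compound 2 still cannot be ranked against each other: the limit of > 40000 nM in this assay, at which 2 of the 3 values shown sit.

From the compounds shown here alone, whether a hydroxyl group or an amine on this aromatic carbon would give a lower number than hydrogen stays open.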